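Alkoxy variation at the aromatic carbon: toward a benzyloxy group

The compounds below may be only part of what the source reports. "The series", "measured", "known", "first", "only" and "open" are said of these compounds alone.

Compound 3 `COCCCOc1nc(C(C)(C)C)ccc1CNC(=O)C(C)c1ccc(NS(C)(=O)=O)c(F)c1` carries a 3-methoxypropoxy group at the aromatic carbon where compound 1 `CC(C(=O)NCc1ccc(C(C)(C)C)nc1N1CCCCCC1)c1ccc(NS(C)(=O)=O)c(F)c1` has azepan-1-yl and compound 2 `CC(C)Oc1nc(C(C)(C)C)ccc1CNC(=O)C(C)c1ccc(NS(C)(=O)=O)c(F)c1` has isopropoxy. In an assay on cells for antagonist activity at transient receptor potential cation channel subfamily V member 1 (Homo sapiens), read by FLIPR and calcium flux, with a stated time of 6 min (on this read-out higher numbers stand for weaker inhibition and lower numbers for stronger inhibition), compound 3 gives 5.6 nM, the highest number of the three; compound 2 gives 2.3 nM and compound 1 gives 0.9 nM. The steps are a 2.6-fold higher number from compound 1 to compound 2 (0.41 log units; beyond the scatter), a 6.2-fold higher number from compound 1 to compound 3 (0.79 log units; beyond the scatter) and a 2.4-fold higher number from compound 2 to compound 3 (0.39 log units; beyond the scatter), all modest and all at this one position.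

Compound 4 `CC(C(=O)NCc1ccc(C(C)(C)C)nc1OCc1ccc(F)cc1)c1ccc(NS(C)(=O)=O)c(F)c1` differs from compound 3 by 4-fluorophenyl in place of 2-methoxyethyl on a saturated chain carbon bound to an oxygen on an aromatic ring. Among the compounds with values here, the one measured step at the same oxygen-linked position, a 2.4-fold higher number from compound 2 to compound 3 (0.39 log units; beyond the scatter), shows that what hangs on the oxygen can move the number beyond the scatter, though only modestly. Within the data shown here, no measured step introduces an aromatic ring at this position, so the direction is open. The three measured compounds span a narrow range, and the expectation for compound 4 is a number near that of compound 3, with a 1.1-fold lower number from compound 3 to compound 4 (0.05 log units; within the scatter) expected to stay within the scatter. The estimate for compound 4 in this assay is 5 nM, with a range from 1.5 nM to 20 nM.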

Compound 4, inhibition constant: 0.8 nM
Estimate against measurement, compound 4: 6.3-fold (0.80 log units) above, and the stated range ends above it.
By their numbers in this assay, from the lowest: compounds 4 and 1 (each within the scatter of the next); then compound 2; then compound 3.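

In this assay, the groups on the oxygen no longer sit in a narrow band: 4-fluorobenzyl on the oxygen gives a 7.0-fold lower number from compound 3 to compound 4 (0.85 log units; beyond the scatter) and a 2.9-fold lower number from compound 2 to compound 4 (0.46 log units; beyond the scatter), both modest steps but beyond the scatter, so a six-membered aromatic ring at this position goes with a lower number than either 3-methoxypropyl or isopropyl. Azepan-1-yl held the lowest number among the earlier compounds, yet a 1.1-fold lower number from compound 1 to compound 4 (0.05 log units; within the scatter) places (4-fluorobenzyl)oxy within the scatter of it, which shows that an oxygen link at this aromatic carbon is compatible with a number as low as that of the azepane compound, and that the alkoxy compounds' higher numbers depend on what the oxygen carries. No supporting measurement accounts for the step, so it stands as a comparison of numbers only.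

The compounds shown do not separate the contribution of the ring from that of its fluorine, a question that plain benzyl or 4-chlorobenzyl on the oxygen would address. Also open, as far as these compounds go, is how a longer link such as 2-phenylethyl, or a saturated ring such as cyclohexylmethyl, would compare at this position.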